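Changing One Arm of a Shared Core

The compounds below may be only part of what the source reports. "The series", "measured", "known", "first", "only" and "open" are said of these compounds alone.

Compound 1 `COc1ccc(-c2nc(/N=C(\N)N(C)C)sc2-c2ccc(OC)cc2)cc1`: in a functional assay with Oryctolagus cuniculus as the target (on this read-out lower numbers stand for stronger inhibition and higher numbers for weaker inhibition), compound 1 gives 37 nM.
Compound 2 `COc1ccc(-c2nc(CNC(=O)c3cccnc3)sc2-c2ccc(OC)cc2)cc1`: in this assay compound 2 gives 25 nM.

Compound 1 has the highest of the two numbers, yet compound 2 sits within the scatter of it. For the measured compounds named here, the only measured step, a 1.5-fold lower number from compound 1 to compound 2 (0.17 log units; within the scatter), exchanged the same group at the same place. Compound 3 `COc1ccc(-c2nc(C(=O)N3CCOCC3)sc2-c2ccc(OC)cc2)cc1` carries a group of 8 heavy atoms (5 carbon, 1 nitrogen, 2 oxygen; one six-membered non-aromatic ring with 2 hetero atoms) in place of a group of 6 heavy atoms (3 carbon, 3 nitrogen; no ring), on an aromatic carbon. Since that measured step stayed within the scatter, no step beyond the scatter is expected here either. For compound 3 the expected step is a 1.1-fold lower number from compound 1 to compound 3 (0.02 log units; within the scatter). Compound 3 is estimated at 35 nM, within a range from 12 nM to 110 nM.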

Compound 3, half-maximal inhibitory concentration: < 10 nM
Compound 3: a limit, no number; the forecaster's own chance of this, stated with the estimate: 3%; middle value at least 3.5-fold (0.54 log units) away from the limit.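

Putting (morpholin-4-yl)carbonyl on this aromatic carbon gives an at least 3.7-fold lower number from compound 1 to compound 3 (0.56 log units; beyond the scatter) and an at least 2.5-fold lower number from compound 2 to compound 3 (0.39 log units; beyond the scatter) in this assay. This position can therefore shift the number beyond the scatter, which the step between the two earlier compounds did not show. The value of compound 3 is a limit and not a number: the limit of < 10 nM in this assay, at which 1 of the 3 values shown sits.

Still open, from the compounds shown here alone, is how far below that limit compound 3 lies, and so how large both steps really are. Going by these compounds, it is also open whether a piperidin-1-ylcarbonyl group, which lacks the morpholine ring oxygen, or a plain carboxylic acid at this place would give a similar number.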